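This account rests on a few compounds, and the source may have more. Where it says the series, first, only, none or still open, it means among the compounds named here.

compound 1 `O=C(Nc1ncc(Cc2ccccn2)s1)C1CCCCC1`: > 40000 nM
compound 2 `O=C(Nc1ncc(Cc2ccncc2)s1)C1CCCCC1`: "not determined" (no result reported)
compound 3 `c1ccc(Cc2cnc(NCCC3CCCCC3)o2)cc1`: "not determined" (no result reported)

All entries come from an ADME assay on P388D1 cells (Mus musculus) for cytotoxicity, read by fluorescence and resazurin assay, with a stated time of 72 h; a higher number here means a weaker inhibitor, a lower number a stronger inhibitor. Compound 1 gives > 40000 nM, which is a limit of the assay and not a number. Compound 2 has no number of its own, its entry being "not determined" (no result reported), so it cannot be placed on any scale. Compound 3 offers no reference either, with "not determined" (no result reported) as its entry.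

The next compound to be measured is compound 4 `O=C(Nc1ncc(CC2CCCC2)s1)C1CCCCC1`, which differs from compound 2 as follows: cyclopentyl in place of pyridin-4-yl on a saturated chain carbon bound to an aromatic carbon. In words, this is cyclopentyl in place of pyridin-4-yl on a saturated chain carbon bound to an aromatic carbon.

With no starting number for compound 2, the size of this change cannot be measured. The working expectation in this assay is a change in neither direction beyond the scatter, and the limit of > 40000 nM in this assay, at which 1 of the 3 values shown sits, is the only anchor. For compound 4 the estimated value is 30000 nM, with an expected range of 10000 nM to 40000 nM.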

Compound 4, half-maximal inhibitory concentration: > 40000 nM
Compound 4: only a limit was reported; the forecaster's own chance of this, stated with the estimate: 65%; at least 1.3-fold (0.12 log units) between middle value and limit.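

No step can be read from compound 1 to compound 4 in this assay: both entries are limits of the assay, not numbers. The compounds shown leave open whether any group on the saturated chain carbon gives a readable value in this assay.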